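Furan to pyrrole on the enone of compound 2

The source may report more compounds than this note shows. Statements on the series, on what has been measured and on what is new or still open speak of the compounds shown alone.

Within the data shown here, compound 2 `COc1ccc(-c2cc3ccccc3nc2/C=C/C(=O)c2ccco2)cc1` is the only compound with a number in a functional assay on NCI-H1299 cells (Homo sapiens) for antiproliferative activity, read by XTT assay, with a stated time of 72 h (a lower number here means a stronger inhibitor, a higher number a weaker inhibitor), giving 730 nM. Compound 1 `COc1ccc(-c2cc3ccccc3nc2C=O)cc1` reaches only a limit of the assay, > 10000 nM (the limit of > 10000 nM in this assay, at which 1 of the 2 values shown sits). Among the measured compounds shown here, the single measured step, an at least 13-fold lower number from compound 1 to compound 2 (1.13 log units; beyond the scatter), concerns the whole 2-((furan-2-yl)carbonyl)ethenyl chain and bears only loosely on the change to compound 3 `COc1ccc(-c2cc3ccccc3nc2/C=C/C(=O)c2ccc[nH]2)cc1`, which is 1H-pyrrol-2-yl in place of furan-2-yl on a carbonyl carbon. For the measured compounds named here, no measured step shares this exchange, so the expectation is a step of no size beyond the scatter, a 1.0-fold lower number from compound 2 to compound 3 (0.02 log units; within the scatter). Compound 3 is therefore estimated at 700 nM, between 250 nM and 2000 nM.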

Compound 3, half-maximal inhibitory concentration: > 10000 nM
Compound 3 was reported as a limit (the forecaster's own chance of this, stated with the estimate: 10%); middle value at least 14-fold (1.15 log units) from the limit.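

In this assay, the ring on the carbonyl carbon proves decisive: 1H-pyrrol-2-yl in place of furan-2-yl gives an at least 13-fold higher number from compound 2 to compound 3 (1.13 log units; beyond the scatter). The gain seen with the 2-((furan-2-yl)carbonyl)ethenyl chain therefore does not extend to the 2-((1H-pyrrol-2-yl)carbonyl)ethenyl chain, although both carry a five-membered aromatic ring with 1 hetero atom. Compound 3 gives only a limit, and the step from compound 1 cannot be read: the limit of > 10000 nM in this assay, at which 2 of the 3 values shown sit.

Open, on these data alone, is whether thiophen-2-yl or 1-methylpyrrol-2-yl on the same carbonyl carbon would keep the number of compound 2, which would help separate the ring itself from the hydrogen on the pyrrole nitrogen.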